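The source may hold more compounds than are shown below. What is called first, only, known or untested is meant among the compounds shown, and "the series" means these compounds.

In a functional assay on A549 cells (Homo sapiens) for inhibition, read by MTT assay, with a stated time of 72 h (on this read-out lower numbers stand for stronger inhibition and higher numbers for weaker inhibition), the measured compounds are:

- Compound 1 (`c1cc(N2CCCCC2)nc(Nc2ccc(Oc3ncnc4sccc34)cc2)n1`): 4020 nM
- Compound 2 (`c1ccc2c(c1)CCN(c1ccnc(Nc3ccc(Oc4ncnc5sccc45)cc3)n1)C2`): 6750 nM

Compound 2 lies within the scatter of compound 1, with a 1.7-fold higher number from compound 1 to compound 2 (0.23 log units; within the scatter). Compound 3 (`CN(c1ccc(Oc2ncnc3sccc23)cc1)c1nccc(N2CCc3ccccc3C2)n1`) differs from compound 2 by one change: methyl in place of hydrogen on a nitrogen on an aromatic ring. Going by the values given here, the only measured step, a 1.7-fold higher number from compound 1 to compound 2 (0.23 log units; within the scatter), concerns a different place, so it says little about this methyl, and no measured compound carries it. No shift beyond the scatter is therefore expected in this assay, though with wide uncertainty. The estimated step is a 1.2-fold higher number from compound 2 to compound 3 (0.07 log units; within the scatter). The expected value for compound 3 is 8000 nM, within a range of 2500 nM to 25000 nM.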

Compound 3, half-maximal inhibitory concentration: 6390 nM
The estimate for compound 3 lay 1.3-fold (0.10 log units) above the measured number; measured number inside the range.
By their numbers in this assay, from the lowest: compounds 1, 3 and 2 (each within the scatter of the next).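

In this assay, methyl in place of hydrogen on a nitrogen on an aromatic ring gives a 1.1-fold lower number from compound 2 to compound 3 (0.02 log units; within the scatter). This is the first step shown at this nitrogen, and it indicates that, with the 1,2,3,4-tetrahydroisoquinolin-2-yl group present, this hydrogen can be replaced by methyl without a shift beyond the scatter. No supporting measurement bears on why the step is this small.

Still open, going by these compounds, is whether an ethyl group, a longer chain or an acetyl group on this nitrogen would behave like methyl. On these data alone, it is also open whether methyl would give a similar step alongside piperidin-1-yl.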